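The source may report more compounds than this note shows. Statements on the series, on what has been measured and on what is new or still open speak of the compounds shown alone.

Going by the values given here, compound 2 `CC1(C)Cc2c(sc(NC(=O)[C@H](O)C(C)(C)C)c2C(N)=O)C(C)(C)O1` stands at the higher of the two numbers measured so far in an assay on cells for positive allosteric modulation of Cystic fibrosis transmembrane conductance regulator variant F508del (Homo sapiens), with stated times of 10 min and 7 s, in the presence of a further agent that is not named here; a higher number here means that more compound is needed for the effect, a lower number that less compound is needed. In this assay compound 2 gives 127 nM, whereas compound 1 `CC1(C)Cc2c(sc(NC(=O)c3ccccc3O)c2C(N)=O)C(C)(C)O1` gives 4 nM. Among the compounds with values here, the only comparison available is the step of a 32-fold higher number from compound 1 to compound 2 (1.50 log units; beyond the scatter), which exchanged the 2-hydroxyphenyl group for the 1-hydroxy-2,2-dimethylpropyl group on the carbonyl carbon. Compound 3 `Cc1cc(C(=O)Nc2sc3c(c2C(N)=O)CC(C)(C)OC3(C)C)[nH]n1` differs from compound 2 in a single place: 3-methyl-1H-pyrazol-5-yl in place of 1-hydroxy-2,2-dimethylpropyl on a carbonyl carbon. Within the data shown here, no measured step covers this exact exchange; the step from compound 1 to compound 2 bears on it, since it shows what happened when an aromatic ring on the carbonyl carbon gave way to the open-chain 1-hydroxy-2,2-dimethylpropyl group. Compound 3 runs that exchange in the opposite direction, returning an aromatic ring to the carbonyl carbon, though a different ring from that of compound 1, so the size of the reversal is uncertain. The step from compound 2 to compound 3 is therefore expected to be an 8.5-fold lower number from compound 2 to compound 3 (0.93 log units; beyond the scatter). For compound 3 the estimate in this assay is 15 nM, expected to fall between 3 nM and 80 nM.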

Compound 3, half-maximal effective concentration: 13 nM
Compound 3: middle estimate off by 1.2-fold (0.06 log units), on the high side; low and high end bracket the measured number.
By their numbers in this assay, from the lowest: compound 1; then compound 3; then compound 2.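

The exchange of 1-hydroxy-2,2-dimethylpropyl for 3-methyl-1H-pyrazol-5-yl on the carbonyl carbon gives a 9.8-fold lower number from compound 2 to compound 3 (0.99 log units; beyond the scatter) in this assay, so a five-membered aromatic ring with 2 hetero atoms, and not only the 2-hydroxyphenyl ring, stands at a lower number than the open-chain group at this position. The two aromatic groups are still not equivalent here: 3-methyl-1H-pyrazol-5-yl in place of 2-hydroxyphenyl gives a 3.3-fold higher number from compound 1 to compound 3 (0.51 log units; beyond the scatter), which leaves compound 1 with the lowest number of the three. The step between compound 2 and compound 3 also comes with no change in size or in the counts of hydrogen-bond donors and acceptors, as both groups have 6 heavy atoms, 1 donor and 1 acceptor, while the ring is gained and the defined stereocentre is lost.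

Nothing available here accounts for these differences in terms of a measured property. From the compounds shown here alone, with only these three compounds, it remains open whether the methyl group on the pyrazole matters, and how a pyridine ring, an unsubstituted pyrazole or an open-chain amine would stand on the same carbonyl carbon.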